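A few compounds are considered here, and "the series" means these few. Any claim that something is new, unique, unknown or untested is made for them only; others in the source may bear on it.

In a functional assay on Jurkat cells (Homo sapiens) (on this read-out higher numbers stand for weaker inhibition and lower numbers for stronger inhibition), compound 1 `CC(C)[C@H](NC(=O)COc1cccc2ccccc12)C(=O)N[C@@H](CC(=O)O)C(=O)COc1ccccc1` gives 14000 nM and compound 2 `CC(C)[C@H](NC(=O)COc1cccc2ccccc12)C(=O)N[C@@H](CC(=O)O)C(=O)COc1ccc(OC(F)(F)F)cc1` gives 29100 nM. Compound 3 `CC(C)[C@H](NC(=O)COc1cccc2ccccc12)C(=O)N[C@@H](CC(=O)O)C(=O)COc1ccc([N+](=O)[O-])cc1` gives > 100000 nM, which is a limit of the assay and not a number. Compound 3 stands on the high-number side of both others, with an at least 7.1-fold higher number from compound 1 to compound 3 (0.85 log units; beyond the scatter) and an at least 3.4-fold higher number from compound 2 to compound 3 (0.53 log units; beyond the scatter). Compound 4 `CC(C)[C@H](NC(=O)COc1cccc2ccccc12)C(=O)N[C@@H](CC(=O)O)C(=O)COc1cc(F)cc(F)c1` differs from compound 3 by 3,5-difluorophenyl in place of 4-nitrophenyl on an oxygen on a saturated carbon. The smaller measured step, a 2.1-fold higher number from compound 1 to compound 2 (0.32 log units; beyond the scatter), came with trifluoromethoxy in place of hydrogen on an aromatic carbon. Within the data shown here, no measured compound carries 3,5-difluorophenyl, so the expectation rests on these steps alone: losing 4-nitrophenyl should bring the number down toward compound 1 and compound 2 in this assay. The expected step is an at least 4.5-fold lower number from compound 3 to compound 4 (0.65 log units; beyond the scatter). For compound 4 the estimated value is 22000 nM, with an expected range of 8000 nM to 70000 nM.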

Compound 4, half-maximal inhibitory concentration: > 100000 nM
Compound 4: a limit, no number (the forecaster's own chance of this, stated with the estimate: 10%); at least 4.5-fold (0.65 log units) between middle value and limit.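

In this assay the value of compound 4 is a limit and not a number. Even so, it gives an at least 7.1-fold higher number from compound 1 to compound 4 (0.85 log units; beyond the scatter) and an at least 3.4-fold higher number from compound 2 to compound 4 (0.53 log units; beyond the scatter), so on this oxygen a ring without a nitro group can also stand well on the high-number side, and all three substituted rings stand there relative to the phenyl of compound 1. The step between compound 3 and compound 4 cannot be read, because both sit at one limit: the limit of > 100000 nM in this assay, at which 2 of the 4 values shown sit.

Going by these compounds, what an amine or a methoxy group on this phenyl ring would do stays open. So does whether any group here can bring the number below that of compound 1.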